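The source may hold more compounds than are shown below. What is called first, only, known or untested is meant among the compounds shown, and "the series" means these compounds.

Measured so far:
compound 1 `CC(C)CC(C)/N=C(\NC#N)Nc1ccncc1` — 35 mg/kg
compound 2 `CC(C)(C)C(C)(C)/N=C(\NC#N)Nc1ccncc1` — 20 mg/kg

The study measures the compounds in a functional assay on the whole organism (blood, strain Wistar-Okamoto) with Rattus norvegicus as the target, with a stated time of 5 days; on this read-out lower numbers stand for an effect already at smaller amounts and higher numbers for an effect only at larger amounts of compound. Compound 1 `CC(C)CC(C)/N=C(\NC#N)Nc1ccncc1` gives 35 mg/kg, and compound 2 `CC(C)(C)C(C)(C)/N=C(\NC#N)Nc1ccncc1` gives 20 mg/kg. Compound 2 stands at the lowest of the two numbers, but its nearest neighbour, compound 1, lies within the scatter of it, so the two values show no separation that can be read as order.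

Compound 3 `CC(C)CC(C)(C)/N=C(\NC#N)Nc1ccncc1` has not yet been measured in this assay. It differs from compound 2 only in the arrangement of the same atoms: isobutyl in place of tert-butyl on a saturated chain carbon bound to a double-bonded nitrogen and two saturated chain carbons. Going by the values given here, no step between measured compounds is known, so nothing here tells how this change acts. Since compound 1 gives 35 mg/kg and compound 2 gives 20 mg/kg, both close to each other, compound 3 is expected near the same values, with a step of a 1.3-fold higher number from compound 2 to compound 3 (0.10 log units; within the scatter) that stays within the scatter. The estimated value for compound 3 is 25 mg/kg, ranging from 12 mg/kg to 50 mg/kg.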

Compound 3, minimum effective dose: 20 mg/kg
Beside the measured number, compound 3's estimate is 1.3-fold (0.10 log units) above it, within the range that was stated.
By their numbers in this assay, from the lowest: compounds 2, 3 and 1 (each within the scatter of the next).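

In this assay, isobutyl in place of tert-butyl on a saturated chain carbon bound to a double-bonded nitrogen and two saturated chain carbons gives no change at the digits printed from compound 2 to compound 3 (within the scatter), so the two arrangements of the same atoms cannot be told apart at this position. Methyl in place of hydrogen at the same carbon gives a 1.8-fold lower number from compound 1 to compound 3 (0.24 log units; within the scatter), and this first step involving a change of size also shows no separation. Nothing available bears on a cause for either result.

The compounds shown leave open whether any group at this position would move the number beyond the scatter, such as a longer chain, a cyclohexyl ring, an amine or a carboxylic acid. They also say nothing about how much of the number depends on this position rather than on the rest of the shared core.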